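A few compounds are considered here, and "the series" means these few. Any claim that something is new, unique, unknown or untested is made for them only; others in the source may bear on it.

In a functional assay on MGC-803 cells (Homo sapiens) for inhibition, read by MTT assay, with a stated time of 72 h (a higher number here means a weaker inhibitor, a lower number a stronger inhibitor), three compounds sharing one core have been measured: compound 1 (`COc1cccc(NC(=O)C2CCN(C/C=C/c3ccccc3)CC2)c1`) gives 37200 nM, compound 2 (`N#Cc1ccc(NC(=O)C2CCN(C/C=C/c3ccccc3)CC2)cc1`) gives 28200 nM and compound 3 (`O=C(Nc1nccs1)C1CCN(C/C=C/c2ccccc2)CC1`) gives 16400 nM. Compound 3 is thus clearly separated from only one of the other two. Going by the values given here, the single modest step is a 2.3-fold lower number from compound 1 to compound 3 (0.36 log units; beyond the scatter), whereas a 1.7-fold lower number from compound 2 to compound 3 (0.24 log units; within the scatter) and a 1.3-fold lower number from compound 1 to compound 2 (0.12 log units; within the scatter) remain small.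

Compound 4 (`O=C(NCc1ccccc1)C1CCN(C/C=C/c2ccccc2)CC1`) brings (benzyl in place of 1,3-thiazol-2-yl on an amide-type nitrogen), that is, benzyl in place of 1,3-thiazol-2-yl on an amide-type nitrogen. Among the compounds with values here, no measured compound carries benzyl, so the three steps bear on this change only indirectly, as exchanges of the group at that same place. All of them are small, so no step beyond the scatter is expected in this assay, with at most a slight drift towards a higher number. The expected step is a 1.5-fold higher number from compound 3 to compound 4 (0.17 log units; within the scatter). For compound 4, the estimate is 24000 nM, with an expected range from 10000 nM to 55000 nM.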

Compound 4, half-maximal inhibitory concentration: > 100000 nM
Compound 4 ended at the assay's limit; the forecaster's own chance of this, stated with the estimate: 10%; at least 4.1-fold (0.61 log units) between middle value and limit.
By their numbers in this assay, from the lowest: compounds 3, 2 and 1 (each within the scatter of the next, the first and the last beyond it). At a limit, above all of these: compound 4.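

In this assay compound 4 reaches a limit of the assay, > 100000 nM, and not a number. Benzyl thereby separates from all three earlier groups, with an at least 6.0-fold higher number from compound 3 to compound 4 (0.78 log units; beyond the scatter), an at least 3.5-fold higher number from compound 2 to compound 4 (0.54 log units; beyond the scatter) and an at least 2.6-fold higher number from compound 1 to compound 4 (0.42 log units; beyond the scatter), so this place on the amide-type nitrogen is more sensitive to exchange than the small or modest steps among 1,3-thiazol-2-yl, 4-cyanophenyl and 3-methoxyphenyl had shown. Each of these steps is only a lower bound on the true difference, and the result rests on a single compound at the limit: the limit of > 100000 nM in this assay, at which 1 of the 4 values shown sits.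

The compounds shown leave open how far compound 4 really lies from the others. They also do not tell whether unsubstituted phenyl, a 2-phenylethyl chain or cyclohexyl on the same nitrogen would behave like benzyl or like the earlier groups.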